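The source may hold more compounds than are shown below. What is called first, only, known or untested is meant among the compounds shown, and "the series" means these compounds.

Measured compounds:
Compound 1 `CCN(CC)S(=O)(=O)c1ccc(S(=O)(=O)N2CCC[C@@H](C(=O)N(C)C(C)C)C2)cc1`: 6200 nM
Compound 2 `CCN(CC)S(=O)(=O)c1ccc(S(=O)(=O)N2CCC[C@@H](C(=O)NC3CN(C(=O)C4CC4)C3)C2)cc1`: 2800 nM
Compound 3 `CCN(CC)S(=O)(=O)c1ccc(S(=O)(=O)N2CCC[C@@H](C(=O)NC3COC3)C2)cc1`: 2300 nM

These three compounds share a core and differ only at the amide end, and all were tested in a functional assay on MIA PaCa-2 cells (Homo sapiens) for inhibition, read by MTT assay, with a stated time of 7 days; on this read-out higher numbers stand for weaker inhibition and lower numbers for stronger inhibition. Compound 3 shows the lowest of the three numbers, but its gap to compound 2 is small: a 1.2-fold lower number from compound 2 to compound 3 (0.09 log units; within the scatter). The gap to compound 1 is larger: a 2.7-fold lower number from compound 1 to compound 3 (0.43 log units; beyond the scatter), and compound 2 sits a similar distance from compound 1: a 2.2-fold lower number from compound 1 to compound 2 (0.35 log units; beyond the scatter).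

Compound 4 `CCN(CC)S(=O)(=O)c1ccc(S(=O)(=O)N2CCC[C@@H](C(=O)NC)C2)cc1` has not been tested in this assay. Its change from compound 3 is methyl in place of oxetan-3-yl on an amide-type nitrogen. The secondary amide is kept; only the group on its nitrogen shrinks. The step from compound 2 to compound 3 bears most directly, as it swapped one such group for another within the scatter, so the identity of this group seems to matter little here. The larger steps from compound 1 reflect a different change on the carbonyl carbon. Compound 4 is therefore expected to show no step beyond the scatter, a 1.3-fold higher number from compound 3 to compound 4 (0.12 log units; within the scatter). Compound 4 is estimated at 3000 nM, with a range from 1200 nM to 7500 nM.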

Compound 4, half-maximal inhibitory concentration: 8600 nM
Estimate against measurement, compound 4: 2.9-fold (0.46 log units) below; the measured number lies above the stated range.
By their numbers in this assay, from the lowest: compounds 3 and 2 (each within the scatter of the next); then compounds 1 and 4 (each within the scatter of the next).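

On the amide-type nitrogen the group does matter in this assay: methyl in place of oxetan-3-yl gives a 3.7-fold higher number from compound 3 to compound 4 (0.57 log units; beyond the scatter) and methyl in place of 1-(cyclopropylcarbonyl)azetidin-3-yl gives a 3.1-fold higher number from compound 2 to compound 4 (0.49 log units; beyond the scatter) even though the swap between those two larger groups stayed within the scatter. A secondary amide alone does not account for the steps away from compound 1, since hydrogen in place of isopropyl gives only a 1.4-fold higher number from compound 1 to compound 4 (0.14 log units; within the scatter) and so the amide hydrogen by itself brings no change beyond the scatter. Nothing measured here gives a reason for these steps.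

From the compounds shown here alone, compounds 2 and 3 both carry a four-membered ring with a hetero atom on this nitrogen, so it remains open whether the ring, its hetero atom or neither goes with their lower numbers. A cyclobutyl group or an open chain such as 2-methoxyethyl at this position would bear on that question.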